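Swapping Carbamoyl for Oxan-4-yl on an Amine Nitrogen

The source may report more compounds than this note shows. Statements on the series, on what has been measured and on what is new or still open speak of the compounds shown alone.

Of the compounds shown here, three have been measured so far in an ADME assay on microsomes from liver (Mus musculus) for metabolic stability, using NADPH, with a stated time of 10 min; on this read-out lower numbers stand for a less stable compound and higher numbers for a more stable compound. Compound 1 `NCCCCN(C[C@H]1Cc2cccnc2CN1)[C@H]1CCCc2cccnc21` gives 69%, compound 2 `NCCCCN(C[C@H]1Cc2nccnc2CN1)[C@H]1CCCc2cccnc21` gives 77%, and compound 3 `NC(=O)NCCCCN(C[C@H]1Cc2ncccc2CN1)[C@H]1CCCc2cccnc21` gives 32%. Compound 3 therefore stands lowest of the three, with the other two above it by more than the usual scatter of repeat measurements.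

The next molecule, compound 4 `c1cnc2c(c1)CN[C@@H](CN(CCCCNC1CCOCC1)[C@H]1CCCc3cccnc31)C2`, has oxan-4-yl in place of carbamoyl on an amine nitrogen. Among the compounds with values here, no measured pair isolates this change, so the evidence is only indirect. Compound 1 and compound 2 also lack the carbamoyl and have the higher values, but their cores differ from that of compound 3, and neither carries oxan-4-yl. A moderate upward move in this assay is expected, with an estimated a number 16 percentage points higher from compound 3 to compound 4 (beyond the scatter), though the uncertainty is wide enough to include no real change. For compound 4 the expected value is 48%, with an estimated range from 24% to 74%.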

Compound 4, percent of the compound remaining: 35%
Beside the measured number, compound 4's estimate is 13 percentage points above it; the measured number falls inside the stated range.
By their numbers in this assay, from the lowest: compounds 3 and 4 (each within the scatter of the next); then compounds 1 and 2 (each within the scatter of the next).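

In this assay the direct pair gives a number 3 percentage points higher from compound 3 to compound 4 (within the scatter) so on this amine nitrogen the two groups cannot be told apart by this read-out. The change itself is not small: carbamoyl, with its hydrogen-bond donor and double bond, gives way to oxan-4-yl, which has no hydrogen-bond donor and brings a six-membered non-aromatic ring and more heavy atoms. Even so, swapping one for the other on the shared core leaves the number within the scatter, which no earlier compound could show. Nothing measured here accounts for this result. Still open, as far as these compounds go, is whether any group on this nitrogen can move the number beyond the scatter on this core, for example an acetyl group or a carboxymethyl group. A single pair also cannot say whether a smaller ether ring, such as oxetan-3-yl, would behave like oxan-4-yl.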